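This account rests on a few compounds, and the source may have more. Where it says the series, first, only, none or still open, it means among the compounds named here.

Measured compounds:
- compound 1, `NS(=O)(=O)c1ccccc1-c1cnc(C(=O)CCCCCCc2ccccc2)o1`: 1500 nM
- compound 2, `O=C(CCCCCCc1ccccc1)c1ncc(-c2cccc(C(=O)C(F)(F)F)c2)o1`: 16 nM
- compound 3, `N#Cc1cccc(-c2cnc(C(=O)CCCCCCc3ccccc3)o2)c1`: 15 nM

All three share a core bearing a long phenyl-capped chain on one side and an aromatic ring on the other. In an assay (Rattus norvegicus) for inhibition of Fatty-acid amide hydrolase 1 (Homo sapiens) (on this read-out higher numbers stand for weaker inhibition and lower numbers for stronger inhibition), compound 3 gives 15 nM, the lowest of the three numbers. Among the compounds with values here, compound 2 sits within the scatter of it, as the single measured step shows: a 1.1-fold lower number from compound 2 to compound 3 (0.03 log units; within the scatter). Compound 1, with 1500 nM in this assay, stands far off, beyond the scatter and weaker on this read-out, which shows that the group attached to the core can matter greatly.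

Compound 4, `O=C(CCCCCCc1ccccc1)c1ncc(-c2ccncn2)o1`, is not yet measured. It differs from compound 3 in one place: pyrimidin-4-yl in place of 3-cyanophenyl on an aromatic carbon. Within the data shown here, no measured step bears directly on this exchange; the one step available swaps groups on a phenyl ring, whereas here the whole ring changes. Since the change is larger than the one measured, a modest shift towards a weaker number is expected for compound 4, with a 2.7-fold higher number from compound 3 to compound 4 (0.43 log units; beyond the scatter). Compound 4 is thus estimated at 40 nM, within a range from 8 nM to 200 nM.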

Compound 4, inhibition constant: 2.3 nM
The estimate for compound 4 lay 17-fold (1.24 log units) above the measured number; the measured number lies below the stated range.
By their numbers in this assay, from the lowest: compound 4; then compounds 3 and 2 (each within the scatter of the next); then compound 1.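

The earlier compounds shown here all carry a phenyl ring at this place on the shared core, next to the ring oxygen, so they show only what happens when a group on that ring changes. Exchanging the ring itself in this assay gives a 6.5-fold lower number from compound 3 to compound 4 (0.81 log units; beyond the scatter), so a carbon-only ring is not needed here for a low number, and pyrimidin-4-yl, a smaller group with 2 hetero atoms in its ring, does better than 3-cyanophenyl. Nothing at hand explains why the number falls with this exchange.

The compounds shown leave open whether a ring with a single nitrogen, such as pyridin-2-yl, or an unsubstituted phenyl ring would give a similar number at this place. They also leave open how pyrimidin-4-yl would fare with a shorter or longer chain, or with an amine on its ring.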